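A few compounds are considered here, and "the series" means these few. Any claim that something is new, unique, unknown or untested is made for them only; others in the source may bear on it.

Compound 1, `COc1cc(C)cc(-c2c(-c3ccnc(-c4ccc(C(C)=O)cc4)c3)cnn2CC#N)c1`: in a functional assay on SF-268 cells (Homo sapiens) for inhibition, read by sulforhodamine B assay, with a stated time of 48 h (a higher number here means that more compound is tolerated, a lower number that less compound is tolerated), compound 1 gives > 100000 nM.
Compound 2, `COc1cc(C)cc(-c2nn(CC#N)cc2-c2ccc(-c3cccc(C(C)=O)c3)nc2)c1`: in this assay compound 2 gives > 100000 nM.
Compound 3, `Cc1cc(O)cc(-c2nn(CC#N)cc2-c2ccnc(-c3ccc(N(C)C)cc3)c2)c1`: in this assay compound 3 gives 77900 nM.

The values for compound 1 and compound 2 are limits of this assay and not numbers; compound 3 is the only one of the three to return a number. Compound 1 therefore sits at the limit of > 100000 nM in this assay, at which 2 of the 3 values shown sit, so its own position on the scale is known only as a bound, not as a point.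

The step to compound 4, `COc1cc(C)cc(-c2c(-c3ccnc(-c4ccc(N(C)C)cc4)c3)cnn2CC#N)c1`, replaces (dimethylamino in place of acetyl on an aromatic carbon), that is, dimethylamino in place of acetyl on an aromatic carbon. Among the measured compounds shown here, no pair of measured compounds differing in exactly this way has been measured, so the size of the step cannot be read off. Compound 3, which carries the dimethylamino group on a related framework, gives a number rather than a limit, and that is the only anchor available. Compound 4 is accordingly expected to land near the upper region of the scale, with the step from compound 1 to compound 4 estimated as an at least 1.1-fold lower number from compound 1 to compound 4 (0.04 log units; that floor lies within the scatter); the estimate for compound 4 is 90000 nM, within 30000 nM to 300000 nM.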

Compound 4, concentration lethal to 50% of the cells: > 100000 nM
Compound 4 gave a limit, no number; the forecaster's own chance of this, stated with the estimate: 55%; at least 1.1-fold (0.04 log units) between middle value and limit.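

Among the compounds shown here, compound 1 and compound 4 both sit at a limit of the assay rather than at a number, and no step between them can be read: the limit of > 100000 nM in this assay, at which 3 of the 4 values shown sit. The compounds shown leave open whether dimethylamino in place of acetyl changes the tolerated concentration at all, and by how much.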